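Swapping a Phenethyl Chain for a Fluorobenzyl Group

The source may hold more compounds than are shown below. What is called first, only, known or untested is meant among the compounds shown, and "the series" means these compounds.

In an assay for binding affinity to Alpha-1B adrenergic receptor (Homo sapiens) (on this read-out higher numbers stand for weaker inhibition and lower numbers for stronger inhibition), compound 3 `CN1CCC[C@@H]1Cn1nc(CCc2ccccc2)c2ccccc2c1=O` gives 200 nM, the lowest of the two numbers here, while compound 1 `CN1CCC[C@@H]1Cn1nc(Cc2ccc(O)cc2)c2ccccc2c1=O` gives 398 nM, which lies within the scatter of compound 3, so the two cannot be told apart. Compound 2 `CN1CCC[C@@H]1Cn1nc(Cc2ccc(C(C)(C)C)cc2)c2ccccc2c1=O` gives > 1990 nM, the limit of the limit of > 1990 nM in this assay, at which 1 of the 3 values shown sits, a boundary of the measurement rather than a number. Compound 4 `CN1CCC[C@@H]1Cn1nc(Cc2ccc(F)cc2)c2ccccc2c1=O` differs from compound 3 by 4-fluorophenyl in place of benzyl on a saturated chain carbon bound to an aromatic carbon. Among the measured compounds shown here, two measured steps bear on this change: a 2.0-fold lower number from compound 1 to compound 3 (0.30 log units; within the scatter), and an at least 5.0-fold higher number from compound 1 to compound 2 (0.69 log units; beyond the scatter). Compound 4 carries a fluorine rather than a tert-butyl on that aromatic carbon, so compound 4 is expected to show a 1.5-fold higher number from compound 3 to compound 4 (0.18 log units; within the scatter). For compound 4 the estimate is 300 nM, ranging from 120 nM to 900 nM.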

Compound 4, inhibition constant: 79.4 nM
Compound 4: middle estimate off by 3.8-fold (0.58 log units), on the high side; the measured number lies below the stated range.
By their numbers in this assay, from the lowest: compound 4; then compounds 3 and 1 (each within the scatter of the next). At a limit, above all of these: compound 2.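

In this assay, the change from phenethyl to 4-fluorobenzyl brings a 2.5-fold lower number from compound 3 to compound 4 (0.40 log units; beyond the scatter), the first lowering here that lies beyond the scatter. On the same aromatic carbon, fluoro in place of hydroxy brings a 5.0-fold lower number from compound 1 to compound 4 (0.70 log units; beyond the scatter), and fluoro in place of tert-butyl brings an at least 25-fold lower number from compound 2 to compound 4 (1.39 log units; beyond the scatter), showing that the group on that carbon can shift the number clearly. The value of compound 2 is a limit: the limit of > 1990 nM in this assay, at which 1 of the 4 values shown sits.

As far as these compounds go, whether chloro or methoxy on that carbon would match fluoro stays open. So does the effect of fluoro on a longer chain, such as phenethyl.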